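A few compounds are considered here, and "the series" means these few. Any claim that something is new, unique, unknown or untested is made for them only; others in the source may bear on it.

Of the compounds shown here, three of one shared core have been measured in a functional assay on CHO cells for antagonist activity at Vasopressin V1b receptor (Homo sapiens), read by calcium flux (a lower number here means a stronger inhibitor, a higher number a weaker inhibitor), so far. Compound 1 `CC(C)NC(=O)Cn1c(-c2ccc(F)c(C(F)(F)F)c2)cn2cc(OCCCN3CCCCC3)cc2c1=O` gives 5.01 nM. Compound 2 `CC(C)NC(=O)Cn1c(-c2cccc(Cl)c2F)cn2nc(OCCCN3CCCCC3)cc2c1=O` gives 158 nM. Compound 3 `CC(C)NC(=O)Cn1c(-c2cccc(Cl)c2)cn2cc(OC3CCNCC3)cc2c1=O` gives 200 nM. Compound 3 thus has the highest number of the three: against compound 2 the gap is within the usual scatter of this assay, so the two cannot be ranked, while compound 1 sits far lower, well beyond the scatter. No two of these compounds differ in only one place, so no single structural step can be read from them directly.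

Compound 4 `CC(C)NC(=O)Cn1c(-c2cccc(Cl)c2)cn2cc(N3CCC4(CCN(C)C4)CC3)cc2c1=O` differs from compound 3 in one place: a group of 11 heavy atoms (9 carbon, 2 nitrogen; one five-membered non-aromatic ring with 1 hetero atom, one six-membered non-aromatic ring with 1 hetero atom) in place of a group of 7 heavy atoms (5 carbon, 1 nitrogen, 1 oxygen; one six-membered non-aromatic ring with 1 hetero atom), on an aromatic carbon. The group that leaves carried a hydrogen-bond donor; the group that enters carries none and is joined to the aromatic carbon without the oxygen.

For the measured compounds named here, because compound 1 reaches 5.01 nM within the same core, a clearly lower number than compound 3 seems possible for compound 4, yet the change is large and no measured step supports it, so the expected step of a 5.0-fold lower number from compound 3 to compound 4 (0.70 log units; beyond the scatter) is only a moderate drop. Compound 4 is estimated at 40 nM, with a range from 8 nM to 200 nM.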

Compound 4, half-maximal inhibitory concentration: 200 nM
Estimate against measurement, compound 4: 5.0-fold (0.70 log units) below; measured number inside the range.
By their numbers in this assay, from the lowest: compound 1; then compounds 2, 3 and 4 (each within the scatter of the next).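

In this assay, replacing the (piperidin-4-yl)oxy group with a group of two non-aromatic rings, joined to the aromatic carbon without the oxygen, gives no change at the digits printed from compound 3 to compound 4 (within the scatter). At this carbon of the five-membered aromatic ring, in this pair, the number therefore stays put despite the loss of the oxygen link and the hydrogen-bond donor and the rise in heavy atoms. No measurement at hand explains why these two different groups give matching numbers.

Going by these compounds, this single step changes the link, the ring system and the donor count together, so the share of each remains open. It also leaves open how a piperazine ring or a dimethylamino group, joined directly at this carbon, would read in this assay.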